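Restoring a methoxy group at a different ring carbon

The compounds below may be only part of what the source reports. "The series", "measured", "known", "first", "only" and "open" are said of these compounds alone.

Compound 2 `CC(=O)NCCSc1ccccc1` gives the highest number of the two measured compounds: in an assay on NIH3T3 cells for displacement of a labelled ligand from melatonin receptor type 1A (Homo sapiens), with a stated time of 90 min (a lower number here means a stronger inhibitor, a higher number a weaker inhibitor), compound 2 gives 3800 nM, whereas compound 1 `COc1cccc(SCCNC(C)=O)c1` gives 55 nM. Compound 3 `COc1ccccc1SCCNC(C)=O` differs from compound 2 by methoxy in place of hydrogen on an aromatic carbon. Among the measured compounds shown here, the one relevant step runs the other way, a 69-fold higher number from compound 1 to compound 2 (1.84 log units; beyond the scatter), but there the methoxy occupies another ring carbon, so a smaller gain is expected for compound 3, a 3.8-fold lower number from compound 2 to compound 3 (0.58 log units; beyond the scatter). Compound 3 is therefore estimated at 1000 nM, plausibly between 150 nM and 6000 nM.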

Compound 3, inhibition constant: 3630 nM
Compound 3: middle estimate off by 3.6-fold (0.56 log units), on the low side; measured number inside the range.
By their numbers in this assay, from the lowest: compound 1; then compounds 3 and 2 (each within the scatter of the next).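

In this assay, methoxy in place of hydrogen, ortho to a group of 7 heavy atoms, gives a 1.0-fold lower number from compound 2 to compound 3 (0.02 log units; within the scatter), so this position shows no measurable gain from the group. The earlier step, a 69-fold higher number from compound 1 to compound 2 (1.84 log units; beyond the scatter), involves methoxy on another ring carbon and lies beyond the scatter, so in these compounds the effect of methoxy depends on which ring carbon carries it. Nothing available here accounts for this difference. Going by these compounds, whether an amine or a hydroxyl group at this same position would change the number remains open.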